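Isoxazole substituent change on the shared core: cyclohexyl to isopropyl

The source may hold more compounds than are shown below. What is called first, only, known or untested is meant among the compounds shown, and "the series" means these compounds.

Measured compounds:
- compound 1, `CC(C)n1nc(-c2cc(C3CCCCC3)on2)c2c(N)ncnc21`: > 10000 nM
- compound 2, `CC(C)(O)Cn1nc(-c2cc(C3CC3)on2)c2c(N)ncnc21`: 4250 nM
- compound 3, `Nc1ncnc2c1c(-c1cc(C3CC3)on1)nn2C1CCOCC1`: 940 nM

In an assay on TT cells for inhibition of proto-oncogene tyrosine-protein kinase receptor Ret variant C634W (Homo sapiens), read by MTT assay, with a stated time of 10 days (on this read-out higher numbers stand for weaker inhibition of growth and lower numbers for stronger inhibition of growth), compound 1 gives only a limit, > 10000 nM, as recorded by the limit of > 10000 nM in this assay, at which 1 of the 3 values shown sits. Going by the values given here, compound 2 gives 4250 nM and compound 3 gives 940 nM, and the one measured step, a 4.5-fold lower number from compound 2 to compound 3 (0.66 log units; beyond the scatter), concerns the group on the aromatic nitrogen and not the five-membered ring bearing oxygen and nitrogen.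

Compound 4, `CC(C)c1cc(-c2nn(C(C)C)c3ncnc(N)c23)no1`, differs from compound 1 by isopropyl in place of cyclohexyl on an aromatic carbon. Among the compounds with values here, no measured step touches this position; compounds 2 and 3 carry cyclopropyl there and give numbers, whereas compound 1 with cyclohexyl sits at the limit, but those pairs differ in more than one place. The smaller group is expected to move compound 4 off the limit, so the step of an at least 2.5-fold lower number from compound 1 to compound 4 (0.39 log units; beyond the scatter) is expected. Compound 4 is estimated at 4000 nM, with a range from 1000 nM to 20000 nM.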

Compound 4, concentration for 50% growth inhibition: 5130 nM
Estimate against measurement, compound 4: 1.3-fold (0.11 log units) below, within the range that was stated.
By their numbers in this assay, from the lowest: compound 3; then compounds 2 and 4 (each within the scatter of the next). At a limit, above all of these: compound 1.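

In this assay, going by these compounds alone, isopropyl in place of cyclohexyl on the aromatic carbon gives the first comparison at this position that differs in one place only: an at least 1.9-fold lower number from compound 1 to compound 4 (0.28 log units; that floor lies within the scatter). With isopropyl, compound 4 gives a number, 5130 nM. Compound 1 stands at a limit. The step is therefore only a floor, its true size is unknown, and the floor alone does not show a change beyond the scatter: the limit of > 10000 nM in this assay, at which 1 of the 4 values shown sits.

The compounds shown leave open how cyclopropyl compares with isopropyl on this carbon with the group on the aromatic nitrogen held constant, as compound 2 and compound 3 differ from compound 4 in that group too. Also open, going by these compounds, is how a methyl, an amine or a carboxylic acid on this carbon would read.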